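The source may hold more compounds than are shown below. What is called first, only, known or untested is meant among the compounds shown, and "the series" means these compounds.

Working notes on the series.

Compound 1 `CN(Cc1cccc(C(=O)O)c1)c1ccc(OCc2c(-c3c(Cl)cccc3Cl)noc2C2CC2)nc1C(F)(F)F` gives 3 nM in an assay on isolated protein for agonist activity at Bile acid receptor (Homo sapiens), read by FRET; a lower number here means that less compound is needed, a higher number that more compound is needed for the effect. Compound 2 `CN(Cc1ccc(C(=O)O)cc1)c1ccc(OCc2c(-c3c(Cl)cccc3Cl)noc2C2CC2)nc1C(F)(F)F` gives 12 nM in this assay, and compound 3 `CN(Cc1ccc(C(=O)NCCS(=O)(=O)O)cc1)c1ccc(OCc2c(-c3c(Cl)cccc3Cl)noc2C2CC2)nc1C(F)(F)F` gives 14 nM. For the measured compounds named here, compound 2 sits second highest of the three numbers; its nearest neighbour is compound 3, and the gap a 1.2-fold higher number from compound 2 to compound 3 (0.07 log units; within the scatter) is small, while the gap a 4.0-fold higher number from compound 1 to compound 2 (0.60 log units; beyond the scatter) is the only step here that is clearly resolved. Both measured steps change the acid end of the molecule and leave the link to the shared core untouched.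

Compound 4 `CC(Nc1ccc(C(=O)O)cc1)c1ccc(OCc2c(-c3c(Cl)cccc3Cl)noc2C2CC2)nc1C(F)(F)F` differs from compound 2 by 1-((4-carboxyphenyl)amino)ethyl in place of (4-carboxybenzyl)(methyl)amino on an aromatic carbon. Neither measured step bears directly on this change, which rebuilds the link between the aromatic core and the carboxyphenyl ring rather than the acid itself. With nothing in the series to anchor the change, a moderate loss is expected, with wide uncertainty in either direction. Compound 4 is therefore estimated at 40 nM in this assay, within 8 nM to 200 nM, which means an expected step of a 3.3-fold higher number from compound 2 to compound 4 (0.52 log units; beyond the scatter).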

Compound 4, half-maximal effective concentration: 101 nM
The estimate for compound 4 lay 2.5-fold (0.40 log units) below the measured number; low and high end bracket the measured number.
By their numbers in this assay, from the lowest: compound 1; then compounds 2 and 3 (each within the scatter of the next); then compound 4.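

Rebuilding the link on the aromatic carbon ortho to the trifluoromethyl group gives an 8.4-fold higher number from compound 2 to compound 4 (0.93 log units; beyond the scatter) in this assay, although the leaving and entering groups have the same heavy atoms. For the compounds shown here, the earlier steps changed only the acid end, so this is the first sign that the way the carboxyphenyl ring is joined to the shared core matters in its own right. The gap widens to a 34-fold higher number from compound 1 to compound 4 (1.53 log units; beyond the scatter), but that pair also differs in where the carboxy group sits on the ring. No measurement shown here accounts for the change.

From the compounds shown here alone, it remains open whether a 1-((3-carboxyphenyl)amino)ethyl group would keep the advantage of compound 1 over compound 2. Going by these compounds, it is equally open whether a methyl group on the nitrogen of the new link would recover any of the number of compound 2.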